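Swapping Dichlorophenyl for Hydroxyphenyl on a Citrate Analogue

This account rests on a few compounds, and the source may have more. Where it says the series, first, only, none or still open, it means among the compounds named here.

Of the compounds shown here, three have been measured in an assay on isolated protein for inhibition of ATP-citrate synthase (Rattus norvegicus); on this read-out lower numbers stand for stronger inhibition and higher numbers for weaker inhibition. Compound 1 `O=C(O)CC(O)(CSCc1ccc(Cl)cc1Cl)C(=O)O` gives 410000 nM, compound 3 `O=C(O)CC(O)(CSCCCCCS(=O)(=O)c1ccc(Cl)cc1Cl)C(=O)O` gives 64000 nM, and compound 2 `O=C(O)CC(O)(CSCCCCCCc1cccc(Cl)c1Cl)C(=O)O` gives 7300 nM. Compound 2 therefore stands as the strongest of the three, and its gap to each of the other two lies beyond the usual scatter of this kind of measurement. From compound 2 the route leads to compound 4 `O=C(O)CC(O)(CSCCCCCCc1ccc(O)cc1)C(=O)O`, which carries 4-hydroxyphenyl in place of 2,3-dichlorophenyl on a saturated chain carbon, six bonds along the chain from a sulfur. The shared core and the chain stay the same; only the ring at the far end of the chain is exchanged. Among the measured compounds shown here, no pair of the measured compounds differs in this single place, so the size of the step rests on judgment rather than on a precedent. The expected step, a 2.7-fold higher number from compound 2 to compound 4 (0.44 log units; beyond the scatter), is a modest loss of potency in this assay, likely beyond the scatter but not a collapse. Compound 4 is accordingly estimated at 20000 nM, with a plausible range from 6000 nM to 70000 nM.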

Compound 4, inhibition constant: 420000 nM
For compound 4 the middle estimate is 21-fold (1.32 log units) below the measured one, and the stated range ends below it.
By their numbers in this assay, from the lowest: compound 2; then compound 3; then compounds 1 and 4 (each within the scatter of the next).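

The ring at the end of the chain, six bonds along from a sulfur, strongly affects the result in this assay: exchanging 2,3-dichlorophenyl for 4-hydroxyphenyl gives a 58-fold higher number from compound 2 to compound 4 (1.76 log units; beyond the scatter) with the shared core and chain unchanged. The chain alone therefore does not secure the strength of compound 2, and this single exchange of ring is enough to lose most of it. No available evidence shows whether the loss follows from removing the two chlorines or from adding the hydroxyl group.

A plain phenyl ring or a 4-methoxyphenyl ring at the same place could help separate these two changes. From the compounds shown here alone, it also remains open whether 2,3-dichlorophenyl would keep its advantage over 4-hydroxyphenyl on a shorter or longer chain.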